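The source may hold more compounds than are shown below. What is called first, only, known or untested is meant among the compounds shown, and "the series" means these compounds.

Measured so far in a functional assay on MCF7 cells (Homo sapiens) for antiproliferative activity, with a stated time of 5 days; a lower number here means a stronger inhibitor, a higher number a weaker inhibitor:
compound 1 `CCCCc1ccc2[nH]c(-c3ccc(OC)cc3)c(C=O)c2c1` gives 22 nM
compound 2 `CCCCc1ccc2[nH]c(-c3ccc(C(F)(F)F)cc3)c(C=O)c2c1` gives 66 nM
compound 3 `CCCCc1ccc2[nH]c(-c3ccc(OC)cc3)c(/C=N\C)c2c1` gives 27 nM

All three share one core. Compound 3 differs from compound 1 at the core by a group of 3 heavy atoms (2 carbon, 1 nitrogen; no ring) in place of a group of 2 heavy atoms (1 carbon, 1 oxygen; no ring), on an aromatic carbon, and the step is a 1.2-fold higher number from compound 1 to compound 3 (0.09 log units; within the scatter). Compound 2 differs from compound 1 by trifluoromethyl in place of methoxy on an aromatic carbon, with a step of a 3.0-fold higher number from compound 1 to compound 2 (0.48 log units; beyond the scatter). Compound 4 `CCCCc1ccc2[nH]c(-c3ccc(C(F)(F)F)cc3)c(/C=N\C)c2c1` is not yet measured; it differs from compound 3 by trifluoromethyl in place of methoxy on an aromatic carbon, the same change as that from compound 1 to compound 2, occurring twice among these compounds. Within the data shown here, the expectation for compound 4 in this assay rests on compound 1 and compound 2, because that pair gave a 3.0-fold higher number from compound 1 to compound 2 (0.48 log units; beyond the scatter) as the only measured instance of this change. The estimated step is a 3.0-fold higher number from compound 3 to compound 4 (0.47 log units; beyond the scatter), taken to match the earlier one in size. Compound 4 is therefore expected to give about 80 nM, with a likely range from 45 nM to 150 nM.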

Compound 4, half-maximal inhibitory concentration: 140 nM
For compound 4 the middle estimate is 1.8-fold (0.24 log units) below the measured one, within the range that was stated.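

In this assay, trifluoromethyl in place of methoxy gives a 5.2-fold higher number from compound 3 to compound 4 (0.71 log units; beyond the scatter), the same direction as on the core of compound 1, and the two steps do not differ beyond the scatter: the same change on two cores in this assay, a 3.0-fold higher number (0.48 log units; beyond the scatter) from compound 1 to compound 2 and a 5.2-fold higher number (0.71 log units; beyond the scatter) from compound 3 to compound 4, 1.7-fold (0.24 log units) apart, within the scatter of two such steps

The second change, a group of 3 heavy atoms (2 carbon, 1 nitrogen; no ring) in place of a group of 2 heavy atoms (1 carbon, 1 oxygen; no ring), gives a 2.1-fold higher number from compound 2 to compound 4 (0.33 log units; beyond the scatter) with trifluoromethyl present, and this too stays within the scatter of its counterpart with methoxy present: the same change on two cores in this assay, a 1.2-fold higher number (0.09 log units; within the scatter) from compound 1 to compound 3 and a 2.1-fold higher number (0.33 log units; beyond the scatter) from compound 2 to compound 4, 1.7-fold (0.24 log units) apart, within the scatter of two such steps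

Both comparisons rest on the same four compounds and so form a single test, which shows the changes carrying over between these cores but not to any other core, and gives no reason for the size of either step.

Still open, on these data alone, is whether an amine or a chlorine atom in place of methoxy would fit the same picture. Also open, as far as these compounds go, is whether these steps would hold with a carboxylic acid in place of the carbonyl group, or with a longer chain in place of butyl.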